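Isopropyl to Cyclopentyl: One Change Tested a Second Time

A few compounds are considered here, and "the series" means these few. Any claim that something is new, unique, unknown or untested is made for them only; others in the source may bear on it.

Of the compounds shown here, three have been measured in a functional assay on HCT-116 cells (Homo sapiens) for antiproliferative activity, read by CCK-8 assay, with a stated time of 72 h, tested at 8 uM; a lower number here means a weaker effect, a higher number a stronger effect of the compound at the concentration tested. Compound 3 `CC(C)n1cnc2c(NCc3ccc(C(=O)Nc4ccccc4N)cc3)nc(Cl)nc21` gives 76%, the highest of the three, with both other values beyond the scatter below it. Compound 2 `CC(C)n1cnc2c(Nc3cccc(Cl)c3)nc(NCOCc3ccc(/C=C/C(=O)Nc4ccccc4N)cc3)nc21` gives 27.9%, and compound 1 `Nc1ccccc1NC(=O)/C=C/c1ccc(COCNc2nc(Nc3cccc(Cl)c3)c3ncn(C4CCCC4)c3n2)cc1` gives 9.19%. Compounds 2 and 1 differ in a single place: cyclopentyl in place of isopropyl on an aromatic nitrogen. Measured directly, that change made a number 18.7 percentage points lower from compound 2 to compound 1 (beyond the scatter), a modest drop.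

Compound 4 `Nc1ccccc1NC(=O)c1ccc(CNc2nc(Cl)nc3c2ncn3C2CCCC2)cc1` is the unmeasured partner of compound 3, and the change between them is the same one: cyclopentyl in place of isopropyl on an aromatic nitrogen. The two place descriptions match word for word. The difference between the core of compound 3 and the core of compound 2, however, is not broken down here, so the earlier step is carried over to a different starting point.

Within the data shown here, the expected step is a number 18 percentage points lower from compound 3 to compound 4 (beyond the scatter), which rests on the one measured instance of this change, a number 18.7 percentage points lower from compound 2 to compound 1 (beyond the scatter). The room around that expectation is widened: the difference between the two cores is not broken down. Compound 4 is therefore estimated at 58%, most likely between 40% and 76%.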

Compound 4, a percentage reported as inhibition, at one concentration (the size of the read-out at that concentration, not a potency): 80.6%
Beside the measured number, compound 4's estimate is 22.6 percentage points below it; measured number outside the range, above it.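

In this assay, cyclopentyl in place of isopropyl on the aromatic nitrogen gives a number 4.6 percentage points higher from compound 3 to compound 4 (within the scatter), so on this core the two compounds cannot be told apart. The change therefore did not carry over as one fixed step from the core of compound 2 to the core of compound 3, and the gap between the two steps is larger than chance alone would readily give: the same change on two cores in this assay, a number 18.7 percentage points lower (beyond the scatter) from compound 2 to compound 1 and a number 4.6 percentage points higher (within the scatter) from compound 3 to compound 4, 23.3 percentage points apart, beyond the scatter of two such steps. This shows that, in these two pairs, the result of the change differs with the core, but it does not show which difference between the cores is responsible or what the change would do on a third core.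

The compounds shown carry only isopropyl or cyclopentyl on that nitrogen, so it remains open how a smaller group such as methyl or a longer chain such as n-butyl would fare there. From the compounds shown here alone, it also remains open whether either step would hold at other concentrations, since each number here comes from a single tested concentration and is not a potency.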